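A few compounds are considered here, and "the series" means these few. Any claim that something is new, unique, unknown or untested is made for them only; others in the source may bear on it.

Compound 3, `C=C[C@]1(C)CC[C@@H](C(=C)COC)C[C@H]1C(=C)C`: 212000 nM in a functional assay on HeLa cells (Homo sapiens) for antiproliferative activity, read by WST assay, with a stated time of 24 h; a higher number here means a weaker inhibitor, a lower number a stronger inhibitor
Compound 1, `C=C[C@]1(C)CC[C@@H](C(=C)COCC)C[C@H]1C(=C)C`: 106000 nM
Compound 2, `C=C[C@]1(C)CC[C@@H](C(=C)CNC2CCCC2)C[C@H]1C(=C)C`: 520 nM

Compound 3 gives the highest number of the three in this assay. Compound 1 stands close to it, since a 2.0-fold higher number from compound 1 to compound 3 (0.30 log units; within the scatter). Compound 2 lies far away: a 410-fold higher number from compound 2 to compound 3 (2.61 log units; beyond the scatter).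

Compound 4, `C=C[C@]1(C)CC[C@@H](C(=C)Cn2ccnc2)C[C@H]1C(=C)C`, differs from compound 3 in one place: 1H-imidazol-1-yl in place of methoxy on a saturated chain carbon bound to a double-bonded chain carbon. Among the compounds with values here, two measured steps bear on this, both at the same place: a 410-fold higher number from compound 2 to compound 3 (2.61 log units; beyond the scatter) and a 200-fold lower number from compound 1 to compound 2 (2.31 log units; beyond the scatter). In both, the cyclopentylamino compound gave a much lower number than an ether. The entering 1H-imidazol-1-yl is a five-membered aromatic ring with 2 hetero atoms, not an amine, so the shift is expected to be smaller but in the same direction; the expected step from compound 3 to compound 4 is an 11-fold lower number from compound 3 to compound 4 (1.03 log units; beyond the scatter). Compound 4 is therefore estimated at 20000 nM, with a range from 3000 nM to 120000 nM.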

Compound 4, half-maximal inhibitory concentration: 15700 nM
Compound 4: middle estimate off by 1.3-fold (0.11 log units), on the high side; the measured number falls inside the stated range.
By their numbers in this assay, from the lowest: compound 2; then compound 4; then compounds 1 and 3 (each within the scatter of the next).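

In this assay, the drop in number at this position is not confined to cyclopentylamino: 1H-imidazol-1-yl also gives a lower number than either ether (a 14-fold lower number from compound 3 to compound 4 (1.13 log units; beyond the scatter); a 6.8-fold lower number from compound 1 to compound 4 (0.83 log units; beyond the scatter)). It stops well short of the amine, however (a 30-fold higher number from compound 2 to compound 4 (1.48 log units; beyond the scatter)), so the entering groups now form a graded series rather than a simple split between amine and ether. No measured evidence here explains these differences.

The compounds shown leave open whether the ring nitrogens matter, which a phenyl ring, with carbon atoms only, would test. They also leave open how an open-chain amine such as diethylamino would compare with cyclopentylamino.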